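Styryl sulfone series: a second methoxy on compound 1

The source may report more compounds than this note shows. Statements on the series, on what has been measured and on what is new or still open speak of the compounds shown alone.

Measured so far:
compound 1, `COc1ccc(/C=C/S(=O)(=O)Cc2ccc(OC)cc2)cc1`: > 20000 nM
compound 2, `COc1ccc(CS(=O)(=O)/C=C/c2ccc(Cl)cc2)cc1`: 3500 nM

In a functional assay on H157 cells (Homo sapiens) for antiproliferative activity, read by trypan blue exclusion (on this read-out lower numbers stand for stronger inhibition and higher numbers for weaker inhibition), compound 1 reaches only the limit of the measurement, > 20000 nM, and no number. Compound 2 gives 3500 nM in this assay. Among the compounds with values here, the one measured step, chloro in place of methoxy on an aromatic carbon, is an at least 5.7-fold lower number from compound 1 to compound 2 (0.75 log units; beyond the scatter); its size is bounded on one side because of the limit of > 20000 nM in this assay, at which 1 of the 2 values shown sits, so the true step may be larger.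

Compound 3, `COc1ccc(CS(=O)(=O)/C=C/c2ccc(OC)c(OC)c2)cc1`, differs from compound 1 by methoxy in place of hydrogen on an aromatic carbon. Within the data shown here, no measured step covers this change: the step from compound 1 to compound 2 concerns an exchange of groups, not an added methoxy, and it bears on compound 3 only in showing that the shared core can move off the limit in this assay. With compound 1 at the limit, the expected step of a number no higher from compound 1 to compound 3 (the limit leaves the size open) is none beyond the scatter. Compound 3 is therefore estimated at 20000 nM in this assay, within 7000 nM to 50000 nM, with a real chance that only a limit is again reported.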

Compound 3, half-maximal inhibitory concentration: > 20000 nM
Compound 3: only a limit was reported; the forecaster's own chance of this, stated with the estimate: 60%; the middle value lies on the limit itself.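

Within the data shown here, no step from compound 1 to compound 3 can be read in this assay, since neither compound gives a number, only a limit: the limit of > 20000 nM in this assay, at which 2 of the 3 values shown sit. The compounds shown leave open whether methoxy in place of hydrogen on an aromatic carbon changes the antiproliferative activity of the shared core at all.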